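This account rests on a few compounds, and the source may have more. Where it says the series, first, only, none or still open, it means among the compounds named here.

Three relatives frame this step: compound 1 `C=CCOc1cc(C2=C(c3cc(OC)c(OC)c(OC)c3)C(=O)C(O)C2)ccc1OC`, compound 2 `COc1ccc(C2=C(c3cc(OC)c(OC)c(OC)c3)C(=O)CC2O[SiH2]C(C)(C)C)cc1OC` and compound 3 `COc1cc(C2=C(c3ccc(OCC(=O)O)cc3)C(O)CC2=O)cc(OC)c1OC`. In an ADME assay on HT-29 cells (Homo sapiens) for cytotoxicity, read by MTT assay, with a stated time of 72 h (on this read-out lower numbers stand for stronger inhibition and higher numbers for weaker inhibition), compound 2 gives > 100 ug/mL, which is a limit of the assay and not a number. Compound 1 gives > 100 ug/mL, also a limit. For compound 3 the entry reads "not determined" (no result reported). That leaves (the limit of > 100 ug/mL in this assay, at which 2 of the 3 values shown sit), so compound 2 has no exact place on the scale. Compound 4 `COc1ccc(C2=C(c3cc(OC)c(OC)c(OC)c3)C(=O)CC2O[SiH2]C(C)(C)C)cc1O` differs from compound 2 at one spot: hydrogen in place of methyl on an oxygen on an aromatic ring, with hydrogen in place of methyl on an oxygen on an aromatic ring, or methoxy to hydroxy. For the measured compounds named here, no measured pair shows this change, so a move towards lower numbers in this assay is expected only tentatively, and its size is uncertain. The expected step of an at least 5.0-fold lower number from compound 2 to compound 4 (0.69 log units; beyond the scatter) is an estimate. For compound 4 the estimated value is 20 ug/mL, within a range from 0.5 ug/mL to 100 ug/mL.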

Compound 4, half-maximal inhibitory concentration: 38 ug/mL
The estimate for compound 4 lay 1.9-fold (0.28 log units) below the measured number, and the stated range covers the measured number.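

In this assay, methoxy to hydroxy, turning 3,4-dimethoxyphenyl into 3-hydroxy-4-methoxyphenyl, gives an at least 2.6-fold lower number from compound 2 to compound 4 (0.42 log units; beyond the scatter). The value for compound 2 is a limit of the assay and not a number, so this step is a minimum. It shows that this one small change can bring a compound onto the measurable scale, which the earlier entries could not show: the limit of > 100 ug/mL in this assay, at which 2 of the 4 values shown sit.

The compounds shown leave open how an amine or a carboxylic acid at this place would read. They also leave open whether methoxy to hydroxy acts alike on other members of the series.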